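The source may hold more compounds than are shown below. What is called first, only, known or untested is meant among the compounds shown, and "the series" means these compounds.

The three measured compounds:

Compound 1 `CCOc1ccccc1-c1ccc(-c2nc3cnccc3c(N[C@@H]3CCOC3=O)c2C#N)cc1` – in a physicochemical assay for lipophilicity, read by HPLC, at pH 7.5 (a lower number here means a more polar compound, a higher number a more lipophilic compound), compound 1 gives 2.7.
Compound 2 `CC[C@@H](Nc1c(C#N)c(-c2ccc(-c3ccccc3OC)cc2)nc2cnccc12)C(N)=O` – compound 2 gives 2.7.
Compound 3 `CCOc1ccccc1-c1ccc(-c2nc3cnccc3c(N[C@H](CC)C(=O)NS(=O)(=O)C3CC3)c2C#N)cc1` – compound 3 gives 2.3.

Compound 2 and compound 1 give the same reading at the digits shown, so nothing separates them in this assay. Compound 3 sits apart: its reading lies lower than that of compound 2 by more than the usual scatter, so compound 2 belongs to the upper pair of the three.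

Compound 4 `CC[C@@H](Nc1c(C#N)c(-c2ccc(-c3ccccc3C)cc2)nc2cnccc12)C(N)=O` has not yet been measured. It differs from compound 2 in a single place: methyl in place of methoxy on an aromatic carbon. Within the data shown here, the only measured step, a number 0.40 log units lower from compound 1 to compound 3 (beyond the scatter), concerns a quite different part of the shared core, the group on the nitrogen on the aromatic ring, and so offers no direct guide to swapping a methoxy for a methyl on the outer aromatic ring. The change itself removes one hydrogen-bond acceptor and one heavy atom, which in this kind of measurement is usually expected to push the reading up by a modest amount, though the pair of numbers here cannot confirm that.

Compound 4 is therefore expected to read 3.1 in this assay, within 2.7 to 3.5, a step of a number 0.40 log units higher from compound 2 to compound 4 (beyond the scatter) that would carry it just beyond the scatter.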

Compound 4, distribution coefficient: 3
Estimate against measurement, compound 4: 0.10 log units above; the measured number falls inside the stated range.
By their numbers in this assay, from the lowest: compound 3; then compounds 1, 2 and 4 (each within the scatter of the next).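

Among these compounds, the earlier compounds offered only a step at the group on the nitrogen, so this is the first reading of a change on an aromatic carbon of the six-membered aromatic ring of carbon only, ortho to a large group. In this assay, methyl in place of methoxy gives a number 0.30 log units higher from compound 2 to compound 4 (within the scatter), so in this one pair the exchange, which also removes the hydrogen-bond acceptor counted for methoxy, does not produce a reading that stands clear of the scatter. Nothing measured here accounts for the size of this step.

Among the compounds shown here, whether an amine, a carboxylic acid or a longer chain at this same place would give a reading beyond the scatter remains open, since methoxy and methyl are the only two groups compared here with everything else held constant. From the compounds shown here alone, the step also comes from a single pair, so it is still unknown whether the same exchange would read alike with a different group on the nitrogen of the shared core.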